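The source may report more compounds than this note shows. Statements on the series, on what has been measured and on what is new or still open speak of the compounds shown alone.

Compound 1 `Clc1ncc(OC[C@@H]2CCN2)cc1/C=C/c1ccncc1` gives 0.009 nM. Compound 2 `Fc1ncc(-c2cc(OC[C@@H]3CCN3)cnc2Cl)cc1Br` gives 0.004 nM.

In an assay on membranes from brain with Neuronal acetylcholine receptor; alpha4/beta2 (Rattus norvegicus) as the target (on this read-out lower numbers stand for stronger inhibition and higher numbers for weaker inhibition), compound 1 stands highest of the two numbers; its nearest neighbour, compound 2, lies beyond the scatter below it. Compound 3 `Clc1ncc(OC[C@@H]2CCN2)cc1/C=C/c1ccnc(Br)c1` differs from compound 1 by bromo in place of hydrogen on an aromatic carbon. Going by the values given here, no measured pair shows what such a change does here, so the step is expected to be small, with no clear direction beyond the scatter. For compound 3 the expected value is 0.008 nM, ranging from 0.002 nM to 0.03 nM, an expected step of a 1.1-fold lower number from compound 1 to compound 3 (0.05 log units; within the scatter).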

Compound 3, inhibition constant: 0.0052 nM
Compound 3: middle estimate off by 1.5-fold (0.19 log units), on the high side; the range from low to high includes it.
By their numbers in this assay, from the lowest: compounds 2, 3 and 1 (each within the scatter of the next, the first and the last beyond it).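

In this assay, the change from pyridin-4-yl to 2-bromopyridin-4-yl gives a 1.7-fold lower number from compound 1 to compound 3 (0.24 log units; within the scatter), so this first measured pair shows that bromo can take the place of hydrogen next to the ring nitrogen with no change beyond the scatter. The high affinity of the core of compound 1 is kept with this larger atom in place. No measurement here offers an explanation for this result.

From the compounds shown here alone, whether an amine, a methoxy group or a longer chain would be accepted at this position remains open. So does the effect of bromo elsewhere on this ring.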